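A Larger Group Replaces Chloro in Compound 1

This account rests on a few compounds, and the source may have more. Where it says the series, first, only, none or still open, it means among the compounds named here.

Compound 1, `Cn1c(-c2ccc(NC(=O)CCl)cc2)nc(-c2ccccc2)c1-c1ccccc1`, gives 14.2% in a functional assay on MCF7 cells (Homo sapiens) for cytotoxicity, read by MTT assay, with a stated time of 24 h, tested at 6.4 ug/mL; on this read-out higher numbers stand for a stronger effect at the one concentration tested and lower numbers for a weaker effect.
Compound 2, `Cn1c(-c2ccc(NC(=O)CSc3nc4ccccc4o3)cc2)nc(-c2ccccc2)c1-c1ccccc1`, gives 42.3% in this assay.

Among the two numbers shown, compound 1 stands lowest; its nearest neighbour is compound 2, and the step between them, a number 28.1 percentage points higher from compound 1 to compound 2 (beyond the scatter), lies beyond the scatter. Compound 3, `Cn1c(-c2ccc(NC(=O)CN3CCN(c4ccccc4)CC3)cc2)nc(-c2ccccc2)c1-c1ccccc1`, is the unmeasured member. It differs from compound 1 in one place: 4-phenylpiperazin-1-yl in place of chloro on a saturated chain carbon bound to a carbonyl carbon.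

Going by the values given here, only one measured step bears on this change. In it the chloro on the saturated chain carbon bound to a carbonyl carbon was exchanged for a large ring-bearing group, and the number rose by a number 28.1 percentage points higher from compound 1 to compound 2 (beyond the scatter). The change to compound 3 removes the same chloro at the same place and brings in another large ring-bearing group, so a rise of similar order is expected in this assay, though the entering group is not the same and the size of the gain may differ. Compound 3 is therefore expected to give a step of a number 19.8 percentage points higher from compound 1 to compound 3 (beyond the scatter). Compound 3 is estimated at 34%, with a range from 16% to 52%.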

Compound 3, a percentage reported as activity, at one concentration (the size of the read-out at that concentration, not a potency): 37.7%
For compound 3 the middle estimate is 3.7 percentage points below the measured one; the range from low to high includes it.
By their numbers in this assay, from the lowest: compound 1; then compounds 3 and 2 (each within the scatter of the next).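

In this assay a second large ring-bearing group on the saturated chain carbon bound to a carbonyl carbon also gives a rise, with 4-phenylpiperazin-1-yl in place of chloro producing a number 23.5 percentage points higher from compound 1 to compound 3 (beyond the scatter) and so showing that the gain among these compounds is not confined to (1,3-benzoxazol-2-yl)sulfanyl. The two large groups differ in their atoms and rings, yet exchanging one for the other gives a number 4.6 percentage points lower from compound 2 to compound 3 (within the scatter) and so this read-out does not separate them at the one concentration tested. Nothing measured here accounts for the rise or shows which part of either entering group carries it.

The compounds shown leave open whether a small amine such as dimethylamino, which has no ring, would also raise the number over chloro, or whether a ring-bearing group is needed for the rise. They also leave open whether a longer chain carrying 4-phenylpiperazin-1-yl would keep the gain, and whether piperidin-1-yl, which lacks the attached phenyl ring, would do the same.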